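Replacing Methylpiperazine with Piperidine on a Fused Core

A few compounds are considered here, and "the series" means these few. Any claim that something is new, unique, unknown or untested is made for them only; others in the source may bear on it.

Compound 2 `CN1CCN(c2nc(-c3ccc(Cl)c(Cl)c3)nc3[nH]cnc23)CC1` gives > 80% in an assay on cells for displacement of a labelled ligand from adenosine receptor A3 (Homo sapiens), read by scintillation counting and radioligand binding, with a stated time of 180 min, tested at 10 uM (a lower number here means less inhibition, a higher number more inhibition at the concentration tested (going by the name of the read-out)), which is a limit of the assay rather than a number. Compound 3 `CN1CCN(c2nc(-c3cccc(Cl)c3)nc3[nH]cnc23)CC1` likewise gives > 80%, again a limit. The step that the two limits leave unreadable from compound 2 to compound 3 therefore cannot be read, and it concerns a different position in any case. Compound 1 `CN1CCN(c2nc(-c3cccc(O)c3)nc3c2ncn3C)CC1` gives 63.8% in this assay but differs from compound 2 in more than one place. Compound 4 `Clc1ccc(-c2nc(N3CCCCC3)c3nc[nH]c3n2)cc1Cl` differs from compound 2 by piperidin-1-yl in place of 4-methylpiperazin-1-yl on an aromatic carbon. Among the measured compounds shown here, no measured step covers this change; the two nearest values share (the limit of > 80% in this assay, at which 2 of the 3 values shown sit). The step of a number at least 8 percentage points lower from compound 2 to compound 4 (that floor lies within the scatter) is expected to be small, possibly hidden by the limit. The estimate for compound 4 is 72%, between 45% and 90%.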

Compound 4, a percentage reported as inhibition, at one concentration (the size of the read-out at that concentration, not a potency): > 80%
Compound 4: a limit, no number (the forecaster's own chance of this, stated with the estimate: 35%); at least 8 percentage points between middle value and limit.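

In this assay, among the compounds shown here, compound 4 gives > 80% as a limit and not a number, so no step from compound 2 can be read. How far piperidin-1-yl and 4-methylpiperazin-1-yl differ therefore stays open: the limit of > 80% in this assay, at which 3 of the 4 values shown sit.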